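A Hydroxyl Returns to the Pendant Ring

A few compounds are considered here, and "the series" means these few. Any claim that something is new, unique, unknown or untested is made for them only; others in the source may bear on it.

Among the compounds with values here, compound 3 `COc1cc(-n2cnc3ccc(-c4ccc(C)cc4F)cc32)cc(OC)c1OC` is the only member of this small set that gives an actual number in a functional assay on SGC-7901 cells (Homo sapiens) for antiproliferative activity, read by MTT assay, with a stated time of 72 h (a lower number here means a stronger inhibitor, a higher number a weaker inhibitor), where compound 3 reaches 5650 nM. Compound 1 `COc1cc(-n2cnc3ccc(-c4ccc(Cl)cc4Cl)cc32)cc(OC)c1OC` reports only a limit of the assay, > 10000 nM, in this assay. Compound 2 `COc1cc(-n2cnc3ccc(-c4ccc(O)cc4)cc32)cc(OC)c1OC` likewise stops at a limit of > 10000 nM. Compound 3 therefore stands alone with a measurable value, while the other two rest at the limit of > 10000 nM in this assay, at which 2 of the 3 values shown sit.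

Compound 4 `COc1ccc(-c2ccc3ncn(-c4cc(OC)c(OC)c(OC)c4)c3c2)cc1O` differs from compound 3 by 3-hydroxy-4-methoxyphenyl in place of 2-fluoro-4-methylphenyl on an aromatic carbon. The nearest measured step runs the other way: an at least 1.7-fold lower number from compound 2 to compound 3 (0.24 log units; that floor lies within the scatter), where a hydroxyl-bearing ring gave way to the 2-fluoro-4-methylphenyl; an at least 1.7-fold lower number from compound 1 to compound 3 (0.24 log units; that floor lies within the scatter) points in the same direction. Compound 4 brings a hydroxyl back onto the pendant ring, together with a methoxy. The step is therefore expected to climb toward weaker inhibition, roughly a 1.8-fold higher number from compound 3 to compound 4 (0.25 log units; within the scatter), with a fair chance that this assay again reports only a limit. Compound 4 is estimated at 10000 nM, between 4000 nM and 30000 nM.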

Compound 4, half-maximal inhibitory concentration: 44 nM
Compound 4: middle estimate off by 230-fold (2.36 log units), on the high side, and the stated range ends above it.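

Within the data shown here, at this position on the shared core, the choice of pendant ring can decide activity in this assay: the record shows a 130-fold lower number from compound 3 to compound 4 (2.11 log units; beyond the scatter), the only new step with an exact number at both ends. A hydroxyl on that ring is not enough by itself, as replacing 4-hydroxyphenyl with 3-hydroxy-4-methoxyphenyl gives an at least 220-fold lower number from compound 2 to compound 4 (2.35 log units; beyond the scatter), and replacing 2,4-dichlorophenyl with it gives an at least 220-fold lower number from compound 1 to compound 4 (2.35 log units; beyond the scatter). Those two sizes are floors rather than exact figures because compound 1 and compound 2 each rest on a limit: the limit of > 10000 nM in this assay, at which 2 of the 4 values shown sit.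

The compounds shown leave open whether the hydroxyl and methoxy are both needed, and whether an amine in place of the hydroxyl or an ethoxy in place of the methoxy would keep this activity. The step between the two compounds at the limit cannot be read.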